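A Benzoyl Group Enters a Series Without Measurable Cytotoxicity

The source may hold more compounds than are shown below. What is called first, only, known or untested is meant among the compounds shown, and "the series" means these compounds.

Of the compounds shown here, three sharing one core have been tested in a functional assay on A549 cells (Homo sapiens) for cytotoxicity, read by MTT assay, with a stated time of 48 h; on this read-out higher numbers stand for weaker inhibition and lower numbers for stronger inhibition. Compound 1, `Cc1nnc(SCC(=O)c2ccccc2)n1N1C(=O)c2ccccc2C1=O`, gives only a limit in this assay, > 200000 nM. Compound 2, `C=CCSc1nnc(CC)n1N1C(=O)c2ccccc2C1=O`, likewise gives only a limit, > 200000 nM. Compound 3, `CCc1nnc(SCc2ccccc2)n1N1C(=O)c2ccccc2C1=O`, again reaches only a limit, > 200000 nM. Because all three values sit at the limit of > 200000 nM in this assay, at which 3 of the 3 values shown sit, compound 3 cannot be placed above or below the other two; it stands at the same limit as they do. For the measured compounds named here, the one step between measured compounds that differ in a single place, a step that the two limits leave unreadable from compound 2 to compound 3, is of a size the two limits leave unreadable.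

Compound 4, `CCc1nnc(SCC(=O)c2ccccc2)n1N1C(=O)c2ccccc2C1=O`, is not yet measured. It differs from compound 3 by benzoyl in place of phenyl on a saturated chain carbon bound to a sulfur. The same benzoyl-bearing sulfur chain is already present in compound 1, which also sits at the limit. Going by the values given here, no measured step shows a readable size, so nothing points to a change beyond the scatter in this assay; the expectation is that compound 4 will again reach only the limit. The expected step is therefore a step that the limit leaves unreadable from compound 3 to compound 4, essentially none. Compound 4 is expected to give about 300000 nM, within 100000 nM to 1000000 nM.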

Compound 4, half-maximal inhibitory concentration: > 200000 nM
Compound 4 was reported as a limit (the forecaster's own chance of this, stated with the estimate: 85%); the middle value is on the limit's open side.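

For the compounds shown here, no step to compound 4 from compound 1, compound 2 or compound 3 can be read in this assay, because all four compounds give only a limit: the limit of > 200000 nM in this assay, at which 4 of the 4 values shown sit.

The compounds shown leave open how strongly any of them inhibits these cells, and whether any change to the group on the sulfur would shift the read-out.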